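This account rests on a few compounds, and the source may have more. Where it says the series, first, only, none or still open, it means among the compounds named here.

Compound 1 `COc1cc2c(Oc3ccc(NC(=O)NN4C(=O)CSC4c4ccccc4)cc3)ccnc2cc1OC1CCN(C(=O)NC(C)C)CC1` gives 1260 nM in a functional assay on HT-29 cells (Homo sapiens) for inhibition, read by MTT assay; a higher number here means a weaker inhibitor, a lower number a stronger inhibitor.
Compound 2 `COc1cc2c(Oc3ccc(NC(=O)NN4C(=O)CSC4c4ccc(F)c(F)c4)cc3)ccnc2cc1OC1CCN(C(=O)NC(C)C)CC1` gives 1060 nM in this assay.
Compound 3 `COc1cc2c(Oc3ccc(NC(=O)NN4C(=O)CSC4c4ccccc4F)cc3)ccnc2cc1OC1CCN(C(=O)NC(C)C)CC1` gives 410 nM in this assay.

Of the three numbers, compound 3 has the lowest, and both gaps to it lie beyond the scatter: a 3.1-fold lower number from compound 1 to compound 3 (0.49 log units; beyond the scatter) and a 2.6-fold lower number from compound 2 to compound 3 (0.41 log units; beyond the scatter). Compound 4 `COc1cc2c(Oc3ccc(NC(=O)NN4C(=O)CSC4c4ccc(F)cc4F)cc3)ccnc2cc1OC1CCN(C(=O)NC(C)C)CC1` differs from compound 3 in one place: fluoro in place of hydrogen on an aromatic carbon. Among the measured compounds shown here, two measured steps bear on this. The step of a 3.1-fold lower number from compound 1 to compound 3 (0.49 log units; beyond the scatter) shows that a fluoro on this phenyl can lower the number, but that fluoro sits at a different position from the one now added. The step of a 1.2-fold lower number from compound 1 to compound 2 (0.08 log units; within the scatter) shows that two further fluoro groups, neither of them at the position of compound 3, change little. A fluoro placed para to the large group is therefore expected to leave the number roughly where compound 3 stands, with no step beyond the scatter in this assay. Compound 4 is estimated at 450 nM, within 200 nM to 1000 nM, an expected step of a 1.1-fold higher number from compound 3 to compound 4 (0.04 log units; within the scatter).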

Compound 4, half-maximal inhibitory concentration: 950 nM
Compound 4: the middle estimate sits 2.1-fold (0.32 log units) below what was measured, and the stated range covers the measured number.
By their numbers in this assay, from the lowest: compound 3; then compounds 4, 2 and 1 (each within the scatter of the next).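

In this assay, the fluoro placed meta to a fluoro group and para to a large group does not add to the gain of the 2-fluorophenyl but removes it, with a 2.3-fold higher number from compound 3 to compound 4 (0.36 log units; beyond the scatter) on this one change. The 2,4-difluorophenyl of compound 4 ends level with the other two compounds, with a 1.1-fold lower number from compound 2 to compound 4 (0.05 log units; within the scatter) and a 1.3-fold lower number from compound 1 to compound 4 (0.12 log units; within the scatter) as the steps that show it. Among these four compounds, only the 2-fluorophenyl of compound 3 stands apart, so the fluoro steps on this phenyl do not simply add up. Nothing measured here gives a reason for this reversal. The compounds shown leave open whether a chloro, methyl or methoxy group at this same place would raise the number as fluoro does. They also leave open whether a 2-chlorophenyl would match the 2-fluorophenyl.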